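Replacing a hydroxyhexyl chain with an oxane ring

The source may hold more compounds than are shown below. What is called first, only, known or untested is meant among the compounds shown, and "the series" means these compounds.

Measured compounds:
- compound 1 `CCCCCCCS(=O)(=O)/C=C/c1ccc(O)c(O)c1`: 7100 nM
- compound 2 `C=CCCCCCS(=O)(=O)/C=C/c1ccc(O)c(O)c1`: 7100 nM
- compound 3 `O=S(=O)(/C=C/c1ccc(O)c(O)c1)CCCCCCCO`: 5900 nM

All three compounds share one core, a catechol joined through a double bond to a sulfonyl group, and differ only in the chain on the other side of that sulfonyl. In a functional assay, read by fluorescence and spectrophotometry, with a stated time of 1 h (on this read-out higher numbers stand for an effect only at larger amounts of compound and lower numbers for an effect already at smaller amounts), compound 3 gives the lowest of the three numbers, yet the step of a 1.2-fold lower number from compound 1 to compound 3 (0.08 log units; within the scatter) and the step of a 1.2-fold lower number from compound 2 to compound 3 (0.08 log units; within the scatter) both lie within the scatter, so the three compounds cannot be told apart on these data. The step of no change at the digits printed from compound 1 to compound 2 (within the scatter) likewise shows nothing beyond the scatter.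

Compound 4 `O=S(=O)(/C=C/c1ccc(O)c(O)c1)CC1CCCCO1` carries a different change: oxan-2-yl in place of 6-hydroxyhexyl on a saturated chain carbon bound to a sulfonyl sulfur. Among the compounds with values here, no measured step alters the carbon bound to the sulfonyl sulfur or closes the chain into a ring, so none bears on this change directly. The three measured steps only show that changes at the far end of the chain leave this assay unmoved. On that basis, and with no further guide, compound 4 is expected to give a number close to that of compound 3, with the step of a 1.1-fold higher number from compound 3 to compound 4 (0.04 log units; within the scatter) estimated to be small. The estimate for compound 4 is 6500 nM, within the range 2500 nM to 17000 nM.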

Compound 4, half-maximal effective concentration: 10800 nM
Compound 4: the middle estimate sits 1.7-fold (0.22 log units) below what was measured, and the stated range covers the measured number.
By their numbers in this assay, from the lowest: compounds 3, 1, 2 and 4 (each within the scatter of the next).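

Compound 4 is the only one of these compounds with a ring on the saturated chain carbon bound to a sulfonyl sulfur, and in this assay all three of its steps stay within the scatter: a 1.8-fold higher number from compound 3 to compound 4 (0.26 log units; within the scatter), a 1.5-fold higher number from compound 2 to compound 4 (0.18 log units; within the scatter), and a 1.5-fold higher number from compound 1 to compound 4 (0.18 log units; within the scatter). On these data, the assay does not separate the oxan-2-yl ring from the open hexyl, hex-5-en-1-yl or 6-hydroxyhexyl chains, so neither an open chain nor the hydrogen-bond donor of 6-hydroxyhexyl is shown to be required at this position. No supporting evidence is available to explain this result.

The compounds shown leave open whether the ring oxygen matters, which a cyclohexyl group at the same position would test. They also leave open whether an amine or a carboxylic acid at the end of the hexyl chain, or a much longer chain, would shift the number beyond the scatter.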